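Mirror-image pair in a methyltransferase inhibitor series

The compounds below may be only part of what the source reports. "The series", "measured", "known", "first", "only" and "open" are said of these compounds alone.

Working notes on a small set of compounds tested in an assay on cells for inhibition of histone-lysine N-methyltransferase EZH2 (Homo sapiens), read by ELISA, with a stated time of 72 h; a higher number here means a weaker inhibitor, a lower number a stronger inhibitor. Compound 1 `Cc1cc(C)c(CN2CCc3c(Cl)cc([C@@H](CO)[C@@H]4CCOC4)c(Cl)c3C2=O)c(=O)[nH]1` gives 2910 nM in this assay and stands as the highest of the two single numbers in the set. Its nearest neighbour is compound 3 `COc1cc(C)[nH]c(=O)c1CN1CCc2c(Cl)cc([C@H](O)C3COC3)c(Cl)c2C1=O`, which in this assay gives 99 nM, a gap beyond the usual scatter. Compound 2 `COC(c1cc(Cl)c2c(c1Cl)C(=O)N(Cc1c(C)cc(C)[nH]c1=O)CC2)C1CCN(C2COC2)CC1` has several entries in this assay, 1310 nM; 16 nM (2 entries); the spread among them is noted as the several entries of compound 2 in this assay, 1310 nM; 16 nM (2 entries) and leaves no single number for that compound.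

The step under consideration leads from compound 1 to compound 4 `Cc1cc(C)c(CN2CCc3c(Cl)cc([C@H](CO)[C@H]4CCOC4)c(Cl)c3C2=O)c(=O)[nH]1`, which is not yet measured in this assay. The change is the two compounds have the same atoms and bonds and differ only in configuration as drawn: 2 of 2 stereo elements differ (all stereocentres are inverted: mirror images); a stereocentre at a saturated chain carbon is drawn S in compound 1 and R in compound 4; a stereocentre at a saturated ring carbon is drawn S in compound 1 and R in compound 4. Among the measured compounds shown here, no step between two measured compounds is available for this kind of change in the set, so the expected size rests on where compound 1 stands and on the two other members, both of which sit at lower numbers.

For compound 4 a lower number than compound 1 is expected, with a step of a 24-fold lower number from compound 1 to compound 4 (1.38 log units; beyond the scatter) that is expected to lie beyond the scatter. The estimate for compound 4 in this assay is 120 nM, in a range from 15 nM to 900 nM.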

Compound 4, half-maximal inhibitory concentration: 10 nM
For compound 4 the middle estimate is 12-fold (1.08 log units) above the measured one, and the stated range ends above it.
By their numbers in this assay, from the lowest: compound 4; then compound 3; then compound 1.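

In this assay, among the compounds shown here, the inversion of both stereocentres gives a 290-fold lower number from compound 1 to compound 4 (2.46 log units; beyond the scatter), the first step in the set that can be read between two measured compounds, and it shows that this part of the molecule is highly sensitive to configuration as drawn. No group leaves or enters, so the step can be tied to configuration alone: the fact that compounds 1 and 4 differ only in the configuration as drawn. The earlier compounds shown here could not show this, as compound 3 differs from compound 1 in more than one place, and compound 2, drawn without configuration at its saturated chain carbon, gives no single number: the several entries of compound 2 in this assay, 1310 nM; 16 nM (2 entries).

Both stereocentres change together in this pair, so the compounds shown do not divide the step between the saturated chain carbon and the saturated ring carbon, and only a compound with one of the two inverted could do so. Also open, going by these compounds, is whether the configuration of compound 4 would keep its advantage with a primary amine or a carboxylic acid in place of the hydroxyl group on its chain.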